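From Pyridin-4-yl to 4-Fluorophenyl at the Assay Limit

The source may report more compounds than this note shows. Statements on the series, on what has been measured and on what is new or still open speak of the compounds shown alone.

Of the compounds shown here, three have so far been tested in a functional assay on MCF7 cells (Homo sapiens) for antiproliferative activity, read by MTT assay, with a stated time of 24 h (a lower number here means a stronger inhibitor, a higher number a weaker inhibitor), and none gives an exact value. Compound 1 (`c1ccc(-c2noc(-c3ccncc3)n2)cc1`) shows > 1000000 nM as a limit, not a number. Going by these compounds, compound 2 (`COc1ccc(-c2noc(-c3ccncc3)n2)cc1OC1CCCC1`) shows > 1000000 nM as a limit too, so its true position is unknown. Compound 3 (`COc1ccc(-c2noc(Cc3c[nH]c4ccccc34)n2)cc1OC1CCCC1`) likewise shows > 1000000 nM as a limit. Compound 4 (`COc1ccc(-c2noc(-c3ccc(F)cc3)n2)cc1OC1CCCC1`) has 4-fluorophenyl in place of pyridin-4-yl on an aromatic carbon of the shared core. Among the compounds with values here, no measured step guides this change, so in this assay the expected at least 1.4-fold lower number from compound 2 to compound 4 (0.15 log units; that floor lies within the scatter) stays within the usual scatter. Compound 4 is estimated near 700000 nM with an expected range of 150000 nM to 1500000 nM and may well return only a limit.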

Compound 4, half-maximal inhibitory concentration: 3880 nM
Estimate against measurement, compound 4: 180-fold (2.26 log units) above, and the stated range ends above it.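

Within the data shown here, putting 4-fluorophenyl in place of pyridin-4-yl gives an at least 250-fold lower number from compound 2 to compound 4 (2.41 log units; beyond the scatter) in this assay, so this position on the shared core can move the read-out, which the earlier compounds could not show. Among these compounds, compound 4 is also the first compound here with an exact value. The true size of the step stays unknown because compound 2 gives only a limit: the limit of > 1000000 nM in this assay, at which 3 of the 4 values shown sit.

The compounds shown leave open whether the fluorine or the carbon-only ring accounts for the change. Going by these compounds, how 4-chlorophenyl or 4-aminophenyl would read at this position is also open.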